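Swapping a Nitrile for tert-Butyl in a Cytotoxicity Series

The source may report more compounds than this note shows. Statements on the series, on what has been measured and on what is new or still open speak of the compounds shown alone.

Two compounds of a shared core have been examined so far in a toxicity assay on NIH3T3 cells (Mus musculus) for cytotoxicity, read by resazurin assay; on this read-out lower numbers stand for an effect already at smaller amounts and higher numbers for an effect only at larger amounts of compound. Compound 1, `COC(=O)c1ccc(NCc2cncn2Cc2cccc(C#N)c2)cc1-c1ccccc1`, gives > 10000 nM in this assay, and this is a limit of the assay rather than a number. Compound 2, `COc1ccc(NCc2cncn2Cc2ccc(-c3ccccc3)cc2N)cc1-c1ccccc1`, gives > 1000 nM in this assay, again only a limit. Compound 1 thus stands at the limit described in the limit of > 10000 nM in this assay, at which 1 of the 2 values shown sits, while compound 2 sits at the one described in the limit of > 1000 nM in this assay, at which 1 of the 2 values shown sits; with both values limits, the two cannot be ordered against each other, and neither shows a measurable effect within the tested range.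

The next compound, compound 3, `COC(=O)c1ccc(NCc2cncn2Cc2cccc(C(C)(C)C)c2)cc1-c1ccccc1`, differs from compound 1 in one place: tert-butyl in place of cyano on an aromatic carbon. Among the measured compounds shown here, no measured step of this kind exists among the tested compounds, so the expectation rests on compound 1 alone. The step that the limit leaves unreadable from compound 1 to compound 3 is expected to be none beyond the scatter, in no particular direction. Compound 3 is therefore expected to give about 15000 nM in this assay, within a range from 5000 nM to 50000 nM, most probably reported once more as a limit rather than a number.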

Compound 3, half-maximal effective concentration: > 1000 nM
Compound 3 ended at the assay's limit (the forecaster's own chance of this, stated with the estimate: 80%); the middle value does not contradict the limit.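

Among the compounds shown here, compound 1 and compound 3 both ended at limits of this assay rather than at numbers, and no step between them can be read. The compounds shown leave open whether tert-butyl in place of cyano on an aromatic carbon alters cytotoxicity at all, and at what concentration any of these compounds would show an effect.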